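Lengthening the chain on a flat cytotoxicity series

The source may report more compounds than this note shows. Statements on the series, on what has been measured and on what is new or still open speak of the compounds shown alone.

Compound 1 `CCCCCC(=O)OCC(C)(C)CC1=C(O)C(=O)c2ccccc2C1=O` gives 169000 nM
Compound 2 `CCCCCCCCC(=O)OCC(C)(C)CC1=C(O)C(=O)c2ccccc2C1=O` gives 150000 nM
Compound 3 `CCCCCCCCCC(=O)OCC(C)(C)CC1=C(O)C(=O)c2ccccc2C1=O` gives 203000 nM

All three values come from an ADME assay on Vero cells (Chlorocebus sabaeus) for cytotoxicity, read by MTT assay (a lower number here means a stronger inhibitor, a higher number a weaker inhibitor), and lie within the scatter of each other, so compound 3 stands level with compound 1 and compound 2. The change to compound 4 `CCCCCCCCCCCC(=O)OCC(C)(C)CC1=C(O)C(=O)c2ccccc2C1=O` is ethyl in place of hydrogen on a saturated chain carbon, nine bonds along the chain from a carbonyl carbon and lengthens the same chain again. The measured steps on this chain bear on it most directly: a 1.1-fold lower number from compound 1 to compound 2 (0.05 log units; within the scatter) then a 1.4-fold higher number from compound 2 to compound 3 (0.13 log units; within the scatter) and overall a 1.2-fold higher number from compound 1 to compound 3 (0.08 log units; within the scatter) all stay within the scatter and show no steady direction. No step beyond the scatter is therefore expected in this assay for this change. The estimate is a 1.1-fold lower number from compound 3 to compound 4 (0.05 log units; within the scatter) and so within the scatter. Compound 4 is expected at 180000 nM with 110000 nM to 300000 nM as its estimated range.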

Compound 4, half-maximal inhibitory concentration: 249000 nM
Compound 4: the middle estimate sits 1.4-fold (0.14 log units) below what was measured; the measured number falls inside the stated range.
By their numbers in this assay, from the lowest: compounds 2, 1, 3 and 4 (each within the scatter of the next).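

Adding ethyl at this position, nine bonds along the chain from a carbonyl carbon, stays within the scatter in this assay with a 1.2-fold higher number from compound 3 to compound 4 (0.09 log units; within the scatter) as its step. Compound 4 also stands level with the shorter chains, with a 1.7-fold higher number from compound 2 to compound 4 (0.22 log units; within the scatter) and a 1.5-fold higher number from compound 1 to compound 4 (0.17 log units; within the scatter) as its steps, so even the largest chain difference shown here produces no real change. No measured evidence explains this flat behaviour.

From the compounds shown here alone, whether a longer chain still, or an amine or a carboxylic acid in place of the chain, would move the number beyond the scatter remains open.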